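The source may hold more compounds than are shown below. What is called first, only, known or untested is meant among the compounds shown, and "the series" means these compounds.

Working notes on the series.

Compound 1 `C/C(=N/NC(=O)Nc1nc(-c2ccc(F)cc2)cc(-c2ccc([N+](=O)[O-])cc2)n1)c1ccc(C)cc1` gives 100 mg/kg in a functional assay on the whole organism (strain Albino) with Mus musculus as the target, with a stated time of 0.5 h; a lower number here means that less compound is needed, a higher number that more compound is needed for the effect. Compound 2 `C/C(=N/NC(=O)Nc1nc(-c2ccc(Cl)cc2)cc(-c2ccc([N+](=O)[O-])cc2)n1)c1ccc(C)cc1` gives 300 mg/kg in this assay. Within the data shown here, the single measured step, chloro in place of fluoro on an aromatic carbon, reads a 3.0-fold higher number from compound 1 to compound 2 (0.48 log units; beyond the scatter). Among the measured compounds shown here, compound 2 therefore stands as the higher of the two numbers, with compound 1 the only neighbour.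

Compound 3 `COc1ccc(-c2cc(-c3ccc(Cl)cc3)nc(NC(=O)N/N=C(/C)c3ccc(C)cc3)n2)cc1` is not yet measured. It differs from compound 2 in one place: methoxy in place of nitro on an aromatic carbon. For the measured compounds named here, no measured step in the set touches this change; the only step seen concerns the halogen, and nothing shows how a methoxy compares with a nitro here. The expectation is therefore a step not beyond the scatter, written as no change at the digits printed from compound 2 to compound 3 (within the scatter), with the range kept wide. Compound 3 is estimated at 300 mg/kg in this assay, between 100 mg/kg and 900 mg/kg.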

Compound 3, dose for half-maximal effect: 300 mg/kg
For compound 3 middle estimate and measured number coincide at the digits printed, within the range that was stated.
By their numbers in this assay, from the lowest: compound 1; then compounds 2 and 3 (each within the scatter of the next).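

In this assay the change from 4-nitrophenyl to 4-methoxyphenyl reads no change at the digits printed from compound 2 to compound 3 (within the scatter) and so stays within the scatter. Among these compounds, the earlier step concerned only the halogen on the other aryl group, so this is the first reading at this position, para to a large group, and it shows that methoxy in place of nitro leaves the number unmoved in the chloro compounds, on this single pair alone. Nothing measured here bears on why the two groups read alike.

Still open, as far as these compounds go, is how an amine, a carboxylic acid or a longer chain such as butoxy would read at this position. Also open, from the compounds shown here alone, is whether the halogen step seen with the 4-nitrophenyl group carries over to compounds with the 4-methoxyphenyl group.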